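The source may hold more compounds than are shown below. What is called first, only, known or untested is meant among the compounds shown, and "the series" means these compounds.

Of the compounds shown here, three built on one shared core have been measured in a functional assay on MGC-803 cells (Homo sapiens) for inhibition, read by MTT assay, with a stated time of 48 h, tested at 20 uM; on this read-out lower numbers stand for less inhibition and higher numbers for more inhibition at the one concentration tested (going by the name of the read-out). Compound 1 `Cn1cnc2c1c(=O)n(CC(=O)N1CCN(C(=O)OC(C)(C)C)CC1)c(=O)n2C` carries a tert-butoxycarbonyl on an amine nitrogen in a ring and gives 20%. Compound 2 `C#CCN1CCN(C(=O)Cn2c(=O)c3c(ncn3C)n(C)c2=O)CC1` carries a propargyl at that place and gives 14.1%; the step of a number 5.9 percentage points lower from compound 1 to compound 2 (within the scatter) stays within the scatter. Compound 3 `C=CC(=O)N1CCN(C(=O)Cn2c(=O)c3c(ncn3C)n(C)c2=O)CC1` carries a vinylcarbonyl there and gives 1.3%, the lowest of the three numbers: the steps of a number 18.7 percentage points lower from compound 1 to compound 3 (beyond the scatter) and a number 12.8 percentage points lower from compound 2 to compound 3 (beyond the scatter) both fall beyond the scatter, so compound 3 stands clearly below compounds 1 and 2.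

Compound 4 `Cc1ccc(S(=O)(=O)N2CCN(C(=O)Cn3c(=O)c4c(ncn4C)n(C)c3=O)CC2)cc1` differs from compound 3 in one place: (4-methylphenyl)sulfonyl in place of vinylcarbonyl on an amine nitrogen in a ring. For the measured compounds named here, no measured step brings in a (4-methylphenyl)sulfonyl, so the change can only be judged from the steps in which the vinylcarbonyl entered. The read-out fell in both a number 18.7 percentage points lower from compound 1 to compound 3 (beyond the scatter) and a number 12.8 percentage points lower from compound 2 to compound 3 (beyond the scatter); with the vinylcarbonyl now leaving, the number is expected to climb back toward the level of compounds 1 and 2 rather than fall further. The step expected is a number 13.7 percentage points higher from compound 3 to compound 4 (beyond the scatter), an upward one beyond the scatter. In this assay compound 4 is therefore estimated at 15%, with a range from 3% to 30%.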

Compound 4, a percentage reported as inhibition, at one concentration (the size of the read-out at that concentration, not a potency): 20.1%
Beside the measured number, compound 4's estimate is 5.1 percentage points below it; measured number inside the range.
By their numbers in this assay, from the lowest: compound 3; then compounds 2, 1 and 4 (each within the scatter of the next).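

In this assay the amine nitrogen in the ring takes a much larger group than any seen so far: the (4-methylphenyl)sulfonyl, with its 10 heavy atoms and its six-membered aromatic ring, gives a number 18.8 percentage points higher from compound 3 to compound 4 (beyond the scatter) when it replaces vinylcarbonyl. Against the other two groups there is no separation, with a number 6 percentage points higher from compound 2 to compound 4 (within the scatter) and a number 0.1 percentage points higher from compound 1 to compound 4 (within the scatter), so tert-butoxycarbonyl, propargyl and (4-methylphenyl)sulfonyl cannot be told apart here, and among the four compounds only the vinylcarbonyl of compound 3 stands apart, now by three steps beyond the scatter. Nothing available explains why this one group stands apart from the other three.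

The compounds shown leave open whether the low number of compound 3 belongs to the carbon-carbon double bond of the vinylcarbonyl or to its carbonyl, a question that a propanoyl or an acetyl on that nitrogen would bear on. They also leave open whether the methyl on the aromatic ring matters, as a plain phenylsulfonyl would show, and how a free amine at that nitrogen would read at this one concentration.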